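The source may report more compounds than this note shows. Statements on the series, on what has been measured and on what is new or still open speak of the compounds shown alone.

Compound 1 `CNC(=O)c1cc(Oc2ccc(C(=O)/C=C/c3cccc([N+](=O)[O-])c3)cc2)ccn1` carries a 3-nitrophenyl group, and in a functional assay on PC-3 cells (Homo sapiens) for cytotoxicity, read by MTT assay, with a stated time of 72 h (on this read-out lower numbers stand for stronger inhibition and higher numbers for weaker inhibition), compound 1 gives "not determined" (no result reported), so it stands nowhere on the scale. Two relatives do have numbers: compound 2 `CNC(=O)c1cc(Oc2ccc(C(=O)/C=C/c3ccc(Cl)cc3Cl)cc2)ccn1` gives 9220 nM, and compound 3 `CNC(=O)c1cc(Oc2ccc(C(=O)/C=C/c3ccc(Br)cc3)cc2)ccn1` gives 18500 nM. Among the compounds with values here, the one measured single change, a 2.0-fold higher number from compound 2 to compound 3 (0.30 log units; within the scatter), lies within the scatter, so exchanging the ring on the chain left the read-out essentially unchanged. Compound 4 `CNC(=O)c1cc(Oc2ccc(C(=O)/C=C/c3ccc(Cl)c(Cl)c3)cc2)ccn1` differs from compound 1 by 3,4-dichlorophenyl in place of 3-nitrophenyl on a double-bonded chain carbon bound to a double-bonded chain carbon. Within the data shown here, because compound 1 has no value, no step from it can be worked out; the result for compound 4 can only be placed near those of compound 2 and compound 3. Compound 4 is expected to give about 10000 nM in this assay, with a range from 4000 nM to 30000 nM.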

Compound 4, half-maximal inhibitory concentration: 8260 nM
The estimate for compound 4 lay 1.2-fold (0.08 log units) above the measured number; the range from low to high includes it.
By their numbers in this assay, from the lowest: compounds 4, 2 and 3 (each within the scatter of the next, the first and the last beyond it).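

In this assay, within the data shown here, the 3,4-dichlorophenyl group gives a 2.2-fold lower number from compound 3 to compound 4 (0.35 log units; beyond the scatter), the first step at this position beyond the scatter, though a modest one. Yet a 1.1-fold lower number from compound 2 to compound 4 (0.05 log units; within the scatter) shows that the two dichlorophenyl groups cannot be told apart here. The step from compound 1 to compound 4 cannot be read, and no supporting data bear on the cause of these differences. Still open, as far as these compounds go, is how a phenyl ring carrying an amine or a carboxylic acid would behave on this double-bonded chain carbon.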